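A sulfonamide replaces the thiazole on the indane core

The source may hold more compounds than are shown below. What is called first, only, known or untested is meant among the compounds shown, and "the series" means these compounds.

Compound 3 `c1cc(-c2nccs2)c2c(c1)C(c1ncc[nH]1)CC2` gives 426 nM in a functional assay on CHO cells for agonist activity at Alpha-1A adrenergic receptor (Homo sapiens), read by FLIPR and calcium flux (on this read-out higher numbers stand for an effect only at larger amounts of compound and lower numbers for an effect already at smaller amounts), one of the two full numbers obtained; the other, from compound 1 `c1ccc2c(c1)CCC2c1ncc[nH]1` at 473 nM, lies within the scatter of it, as a 1.1-fold lower number from compound 1 to compound 3 (0.05 log units; within the scatter) states. Compound 2 `Cn1cc(-c2cccc3c2CCC3c2ncc[nH]2)cn1` reached only a limit, > 2900 nM, so the limit of > 2900 nM in this assay, at which 1 of the 3 values shown sits, applies. Against that limit, an at least 6.1-fold higher number from compound 1 to compound 2 (0.78 log units; beyond the scatter) and an at least 6.8-fold lower number from compound 2 to compound 3 (0.83 log units; beyond the scatter) are the only steps beyond the scatter. Compound 4 `CCS(=O)(=O)Nc1cccc2c1CCC2c1ncc[nH]1` arises through ((ethylsulfonyl)amino in place of 1,3-thiazol-2-yl on an aromatic carbon). Among the compounds with values here, no measured step covers such a group, and the two numbers from hydrogen and the thiazolyl agree, while the pyrazolyl hurt. Compound 4 is therefore expected to shift by a 2.1-fold higher number from compound 3 to compound 4 (0.32 log units; beyond the scatter), and its estimated value is 900 nM, within 250 nM to 3500 nM.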

Compound 4, half-maximal effective concentration: 32 nM
For compound 4 the middle estimate is 28-fold (1.45 log units) above the measured one, and the stated range ends above it.
By their numbers in this assay, from the lowest: compound 4; then compounds 3 and 1 (each within the scatter of the next). At a limit, above all of these: compound 2.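

In this assay, within the data shown here, the earlier groups on this aromatic carbon either stayed within the scatter of hydrogen or raised the number, whereas (ethylsulfonyl)amino is the first to lower it, with a 15-fold lower number from compound 1 to compound 4 (1.17 log units; beyond the scatter) and a 13-fold lower number from compound 3 to compound 4 (1.12 log units; beyond the scatter) as the result. Unlike 1,3-thiazol-2-yl, it has no ring and carries a hydrogen-bond donor, though these compounds cannot separate the two features. Compound 2 stands at a limit, so an at least 90-fold lower number from compound 2 to compound 4 (1.95 log units; beyond the scatter) is only a bound: the limit of > 2900 nM in this assay, at which 1 of the 4 values shown sits.

The compounds shown leave open whether the ethyl chain, the sulfonyl or the amino hydrogen matters. A longer chain on the sulfonyl, an amide carbonyl in its place or a plain amine on this carbon would help to tell these apart.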